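The compounds below may be only part of what the source reports. "The series", "measured", "known", "first", "only" and "open" are said of these compounds alone.

Measured so far:

- Compound 1 `C=CCn1c(=O)/c(=C\c2cccc(Br)c2)[nH]c(=O)/c1=C\c1ccccc1OC` gives 5400 nM in a functional assay on A549 cells (Homo sapiens) for cytotoxicity, read by CCK-8 assay, with a stated time of 72 h; a lower number here means a stronger inhibitor, a higher number a weaker inhibitor.
- Compound 2 `C=CCn1c(=O)/c(=C\c2ccccc2C(F)(F)F)[nH]c(=O)/c1=C\c1ccccc1OC` gives 7000 nM in this assay.
- Compound 3 `C=CCn1c(=O)/c(=C\c2cccc(C)c2)[nH]c(=O)/c1=C\c1ccccc1OC` gives 22700 nM in this assay.

All three share the same core and differ only in the ring hanging from one double-bonded chain carbon. Compound 3, which carries the 3-methylphenyl there, stands with the highest number of the three, so it is the weakest of this small set: its step from compound 1 is a 4.2-fold higher number from compound 1 to compound 3 (0.62 log units; beyond the scatter) and its step from compound 2 is a 3.2-fold higher number from compound 2 to compound 3 (0.51 log units; beyond the scatter), both beyond the usual scatter. The step from compound 1 to compound 2, a 1.3-fold higher number from compound 1 to compound 2 (0.11 log units; within the scatter), lies within the scatter, so those two cannot be ranked against each other.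

Compound 4 `C=CCn1c(=O)/c(=C\c2ccccc2F)[nH]c(=O)/c1=C\c1ccccc1OC` is the next variation: 2-fluorophenyl in place of 3-methylphenyl on a double-bonded chain carbon bound to an aromatic carbon. Both measured steps that end at compound 3 bear on this change, since each replaces the 3-methylphenyl of compound 3 with a ring bearing bromo or trifluoromethyl and each gave a lower number, of modest size. A fluoro-bearing ring is not among the measured examples, so the direction is borrowed rather than shown. On that basis compound 4 is expected to show a modest move toward a lower number, estimated as a 2.8-fold lower number from compound 3 to compound 4 (0.45 log units; beyond the scatter).

Compound 4 is therefore estimated at 8000 nM in this assay, with a likely range from 3000 nM to 20000 nM.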

Compound 4, half-maximal inhibitory concentration: "not active" (no number reported)
Compound 4 has no reported number here; the estimate stays without a comparison.
By their numbers in this assay, from the lowest: compounds 1 and 2 (each within the scatter of the next); then compound 3.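

In this assay, going by these compounds alone, compound 4 is reported as not active, with no number, so no step from compound 3 or any other compound to compound 4 can be read. No measured evidence here bears on this result. The compounds shown leave open how far compound 4 lies from compound 3 on this scale.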